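Chloro for hydrogen on two related fused cores

The compounds below may be only part of what the source reports. "The series", "measured", "known", "first", "only" and "open" are said of these compounds alone.

Measured compounds:
compound 1 `ClCc1ccccc1Cn1cnc2c(Cl)nc(Cl)nc21`, 6910 nM
compound 2 `ClCc1ccccc1Cn1cnc2c(Cl)ncnc21`, 85100 nM
compound 3 `ClCc1ccccc1Cn1cnc2ncnc(Cl)c21`, 85100 nM

In a functional assay on SK-OV-3 cells (Homo sapiens) for cytotoxicity, read by sulforhodamine B assay, with a stated time of 48 h (on this read-out higher numbers stand for lower toxicity in this test and lower numbers for higher toxicity in this test), compound 1 gives 6910 nM, compound 2 gives 85100 nM and compound 3 gives 85100 nM. Compound 2 and compound 3 share the same atoms joined differently; the difference between the two cores is not broken down here, and their values lie level at the digits shown. One change has been measured once: chloro in place of hydrogen on an aromatic carbon, giving a 12-fold lower number from compound 2 to compound 1 (1.09 log units; beyond the scatter).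

Compound 4 `ClCc1ccccc1Cn1cnc2nc(Cl)nc(Cl)c21` is not yet measured. For the measured compounds named here, it arises from compound 3 by chloro in place of hydrogen on an aromatic carbon, which is the same change as the one from compound 2 to compound 1, with the place described in identical words. Going by the values given here, the step from compound 3 to compound 4 is expected to be a 12-fold lower number from compound 3 to compound 4 (1.08 log units; beyond the scatter), resting on the single measured step of a 12-fold lower number from compound 2 to compound 1 (1.09 log units; beyond the scatter) and on compound 3 standing at 85100 nM, level with compound 2. Compound 4 is therefore estimated at 7000 nM, between 2500 nM and 25000 nM in this assay.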

Compound 4, concentration lethal to 50% of the cells: 56200 nM
The estimate for compound 4 lay 8.0-fold (0.90 log units) below the measured number; measured number outside the range, above it.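

In this assay, chloro in place of hydrogen on an aromatic carbon gives a 1.5-fold lower number from compound 3 to compound 4 (0.18 log units; within the scatter), so the change does not keep its size on this second core. The two readings of the same change differ: the same change on two cores in this assay, a 12-fold lower number (1.09 log units; beyond the scatter) from compound 2 to compound 1 and a 1.5-fold lower number (0.18 log units; within the scatter) from compound 3 to compound 4, 8.1-fold (0.91 log units) apart, beyond the scatter of two such steps. A step measured on one core therefore cannot simply be carried to the other in this series, even where the change is described in identical words, but these data do not show why the two cores part, and with one step per core they give no rule for any further core.

On these data alone, it remains open whether other groups on the aromatic carbon between two ring nitrogen atoms, such as an amine or a methoxy group, would depend on the core in the same way. Also open, as far as these compounds go, is whether a longer chain in place of the chloromethyl group would leave the gap between the two steps unchanged.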